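The compounds below may be only part of what the source reports. "The series", "measured", "known", "first", "only" and "open" are said of these compounds alone.

Measured so far:
Compound 1 `Cn1c(-c2ccc(NC(=O)CCl)cc2)nc(-c2ccccc2)c1-c1ccccc1` gives 23.7% in a functional assay on HT-29 cells (Homo sapiens) for cytotoxicity, read by MTT assay, with a stated time of 24 h, tested at 16 ug/mL; on this read-out higher numbers stand for a stronger effect at the one concentration tested and lower numbers for a weaker effect.
Compound 2 `Cn1c(-c2ccc(NC(=O)CSc3nc4cc(Cl)ccc4o3)cc2)nc(-c2ccccc2)c1-c1ccccc1` gives 42.5% in this assay.
Compound 3 `Cc1ccc2oc(SCC(=O)Nc3ccc(-c4nc(-c5ccccc5)c(-c5ccccc5)n4C)cc3)nc2c1` gives 37.7% in this assay.

Compound 3 stands second highest of the three numbers; its nearest neighbour is compound 2, and the gap between them, a number 4.8 percentage points lower from compound 2 to compound 3 (within the scatter), is within the scatter, while the gap to compound 1, the lowest, is beyond it. Compound 4 `Cn1ccnc1SCC(=O)Nc1ccc(-c2nc(-c3ccccc3)c(-c3ccccc3)n2C)cc1` differs from compound 3 in one place: 1-methyl-1H-imidazol-2-yl in place of 5-methyl-1,3-benzoxazol-2-yl on a sulfur. Going by the values given here, no measured step exchanges one heteroaryl on that sulfur for another. Among the compounds with values here, the steps that bear on it are those that introduced a heteroaryl sulfanyl onto the chain carbon: a number 18.8 percentage points higher from compound 1 to compound 2 (beyond the scatter) and a number 14 percentage points higher from compound 1 to compound 3 (beyond the scatter), both modest rises in this assay. Compound 4 keeps a heteroaryl sulfanyl, but the group entering is smaller than the one leaving, so a number near compound 3 or somewhat lower is expected, with a step of about a number 5.7 percentage points lower from compound 3 to compound 4 (within the scatter). Compound 4 is therefore estimated at 32%, in the range 20% to 44%.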

Compound 4, a percentage reported as activity, at one concentration (the size of the read-out at that concentration, not a potency): 36.5%
For compound 4 the middle estimate is 4.5 percentage points below the measured one, and the stated range covers the measured number.
By their numbers in this assay, from the lowest: compound 1; then compounds 4, 3 and 2 (each within the scatter of the next).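

On the sulfur, the two-ring 5-methyl-1,3-benzoxazol-2-yl can give way to the one-ring 1-methyl-1H-imidazol-2-yl, with fewer heavy atoms entering than leaving, and this assay does not separate the two: the result is a number 1.2 percentage points lower from compound 3 to compound 4 (within the scatter) and, against the 5-chloro-1,3-benzoxazol-2-yl, a number 6 percentage points lower from compound 2 to compound 4 (within the scatter). The six-membered aromatic ring of carbon only is thus not required for the rise over the chloro compound, which stands at a number 12.8 percentage points higher from compound 1 to compound 4 (beyond the scatter) and holds for all three heteroaryl sulfanyl groups shown. Nothing in the data shown accounts for this result. As far as these compounds go, whether a plain phenyl or a morpholine on the sulfur would hold the same level remains open. So does the effect of a longer chain on the sulfur or of an amine in place of the sulfur.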